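A few compounds are considered here, and "the series" means these few. Any claim that something is new, unique, unknown or untested is made for them only; others in the source may bear on it.

Compound 2 (`CN(C)C(=O)N1CCC[C@H]1C(=O)N1CCC(NS(=O)(=O)c2cc(S(=O)(=O)c3ccccc3)ccc2C(F)(F)F)CC1`) stands highest of two numbers in a physicochemical assay for solubility (a lower number here means a less soluble compound, a higher number a more soluble compound), at 100000 nM while compound 1 (`CC(C)(C)OC(=O)N1CCC[C@@H]1C(=O)N1CCC(NS(=O)(=O)c2cc(S(=O)(=O)c3ccccc3)ccc2C(F)(F)F)CC1`) reads 25000 nM on the same scale. Compound 3 (`O=C([C@@H]1CCCN1Cc1ccccc1)N1CCC(NS(=O)(=O)c2cc(S(=O)(=O)c3ccccc3)ccc2C(F)(F)F)CC1`) carries benzyl in place of dimethylcarbamoyl on an amine nitrogen in a ring. Among the measured compounds shown here, only one measured step changes the group on that nitrogen (a 4.0-fold higher number from compound 1 to compound 2 (0.60 log units; beyond the scatter)) and it was modest but beyond the scatter. For the measured compounds named here, with only that step as a guide, a change of similar size toward a lower number is expected in this assay (a 3.3-fold lower number from compound 2 to compound 3 (0.52 log units; beyond the scatter)). Compound 3 is estimated at 30000 nM within a range of 8000 nM to 100000 nM for this measurement.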

Compound 3, solubility: 25000 nM
Compound 3: middle estimate off by 1.2-fold (0.08 log units), on the high side; the range from low to high includes it.
By their numbers in this assay, from the lowest: compounds 1 and 3 (each within the scatter of the next); then compound 2.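

In this assay, a third group on the amine nitrogen in the ring shows that the higher number of compound 2 does not carry over to benzyl: the step reads a 4.0-fold lower number from compound 2 to compound 3 (0.60 log units; beyond the scatter) in this series. Set against the tert-butoxycarbonyl group, benzyl gives no change at the digits printed from compound 1 to compound 3 (within the scatter), so among these three groups only dimethylcarbamoyl stands apart. Nothing measured here explains this result. The compounds shown leave open how a smaller group such as methyl, or a chain ending in a carboxylic acid, would read on that nitrogen.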